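From 3-aminopyrazin-2-yl to 4-methylphenyl on a shared core

The source may hold more compounds than are shown below. What is called first, only, known or untested is meant among the compounds shown, and "the series" means these compounds.

In a functional assay on HeLa cells (Homo sapiens) for cytotoxicity, read by MTT assay, with a stated time of 48 h (on this read-out lower numbers stand for stronger inhibition and higher numbers for weaker inhibition), compound 1 `Cc1nc2c3ccccc3ccc2c2nc3c(ccc4ccccc43)c(-c3cccc([N+](=O)[O-])c3)c12` gives 50700 nM and compound 2 `Cc1nc2c3ccccc3ccc2c2nc3c(ccc4ccccc43)c(-c3nccnc3N)c12` gives 1210 nM, so compound 2 holds the lower of the two numbers. Compound 3 `Cc1ccc(-c2c3ccc4ccccc4c3nc3c2c(C)nc2c4ccccc4ccc32)cc1` has not yet been measured. It keeps the shared core but carries 4-methylphenyl in place of 3-aminopyrazin-2-yl on an aromatic carbon. Within the data shown here, one measured step bears on this change: a 42-fold lower number from compound 1 to compound 2 (1.62 log units; beyond the scatter), a large step that put 3-aminopyrazin-2-yl in place of 3-nitrophenyl. The entering ring is of carbon only, like the ring of compound 1 at 50700 nM, so the number is expected to move back up in this assay, probably not all the way. The expected size of this rise, beyond the scatter, is a 12-fold higher number from compound 2 to compound 3 (1.09 log units; beyond the scatter). For compound 3 the estimate is 15000 nM, with an expected range of 3000 nM to 60000 nM.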

Compound 3, half-maximal inhibitory concentration: 72200 nM
Estimate against measurement, compound 3: 4.8-fold (0.68 log units) below; measured number above the stated range.
By their numbers in this assay, from the lowest: compound 2; then compounds 1 and 3 (each within the scatter of the next).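

In this assay, the new step is a 60-fold higher number from compound 2 to compound 3 (1.78 log units; beyond the scatter), so the low number of compound 2 does not survive when 4-methylphenyl enters at this position. The two compounds with a ring of carbon only cannot be told apart, at a 1.4-fold higher number from compound 1 to compound 3 (0.15 log units; within the scatter), even though 3-nitrophenyl and 4-methylphenyl are different groups; among these three compounds, only the one with 3-aminopyrazin-2-yl stands apart. Nothing available explains this difference.

The 3-aminopyrazin-2-yl group differs from both carbon rings in two ways at once, in its ring nitrogens and in its amine, so the compounds shown cannot say which of these goes with the lower number. A pyrazin-2-yl ring without the amine and a 3-aminophenyl ring would separate the two.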